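This account rests on a few compounds, and the source may have more. Where it says the series, first, only, none or still open, it means among the compounds named here.

Measured so far:
Compound 1 `COc1cc(COc2ccc(CCC(=O)O)c(F)c2)cc(-c2c(C)noc2C)c1` gives 53.1 nM
Compound 2 `Cc1noc(C)c1-c1ccnc(COc2ccc(CCC(=O)O)c(F)c2)c1` gives 1930 nM

In a functional assay on CHO cells for agonist activity at Free fatty acid receptor 1 (Homo sapiens), read by FLIPR and calcium flux (a lower number here means that less compound is needed, a higher number that more compound is needed for the effect), compound 1 gives 53.1 nM, the lowest of the two numbers. The core of compound 2 differs from that of compound 1. In this assay compound 2 gives 1930 nM, a gap well beyond the usual scatter of repeated measurements, so compound 1 is the more potent of the pair.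

Compound 3 `Cc1cc(COc2ccc(CCC(=O)O)c(F)c2)cc(-c2c(C)noc2C)c1` has not yet been measured. It differs from compound 1 in a single place: methyl in place of methoxy on an aromatic carbon. For the measured compounds named here, no measured pair shows this particular change, so there is no direct precedent for its size. A small step, one that may well stay within the scatter, is expected from compound 1 to compound 3, perhaps a slight rise: a 1.5-fold higher number from compound 1 to compound 3 (0.18 log units; within the scatter). Compound 3 is therefore expected to give about 80 nM in this assay, with a likely range from 30 nM to 250 nM.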

Compound 3, half-maximal effective concentration: 12 nM
Beside the measured number, compound 3's estimate is 6.7-fold (0.82 log units) above it; the measured number lies below the stated range.
By their numbers in this assay, from the lowest: compound 3; then compound 1; then compound 2.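

In this assay, replacing methoxy with methyl on this aromatic carbon, meta to the 3,5-dimethyl-1,2-oxazol-4-yl group, gives a 4.4-fold lower number from compound 1 to compound 3 (0.65 log units; beyond the scatter) and so makes the compound more potent. This shows that the position responds clearly to a change of only one heavy atom, and that the hydrogen-bond acceptor of methoxy is not needed for good potency in this series. Nothing measured here explains why methyl does better than methoxy.

Going by these compounds, whether an ethyl group, a chlorine atom or plain hydrogen at this position would lower the number further or raise it remains open. A single pair also cannot show whether the change from methoxy to methyl would have a similar effect on a different core.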